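Aromatase inhibition: phenyl for chloro on the aryl ether

The compounds below may be only part of what the source reports. "The series", "measured", "known", "first", "only" and "open" are said of these compounds alone.

Compound 1 `Clc1ccc(OCc2cn(C(c3ccccc3)c3ccccc3)nn2)cc1` — 13400 nM
Compound 2 `N#Cc1ccc(Cn2cc(COc3ccc(-c4ccccc4)cc3)nn2)cc1` — 11600 nM
Compound 3 `Clc1ccc(OCc2cn(Cc3ccccc3)nn2)cc1` — 5040 nM

Three compounds were tested in an assay on isolated protein for inhibition of Aromatase (Homo sapiens), read by fluorescence and colorimetric assay, with a stated time of 30 min; a higher number here means a weaker inhibitor, a lower number a stronger inhibitor. Compound 3 gives the lowest number of the three; compound 2 sits a bit higher and compound 1 higher still. Among the measured compounds shown here, the only one-place step, a 2.7-fold lower number from compound 1 to compound 3 (0.42 log units; beyond the scatter), touches the substituent on the triazole nitrogen and not the aryl ether. Compound 4 `c1ccc(Cn2cc(COc3ccc(-c4ccccc4)cc3)nn2)cc1` differs from compound 3 by phenyl in place of chloro on an aromatic carbon. For the measured compounds named here, no measured step isolates this change; compound 2 carries the same phenyl but also a nitrile on the benzyl group, so its value and that of compound 3 only hint at the direction. On that basis a modest rise in the number is expected for compound 4, a 1.7-fold higher number from compound 3 to compound 4 (0.23 log units; within the scatter), giving an estimate of 8500 nM with a range from 3000 nM to 25000 nM.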

Compound 4, half-maximal inhibitory concentration: 10700 nM
For compound 4 the middle estimate is 1.3-fold (0.10 log units) below the measured one; measured number inside the range.
By their numbers in this assay, from the lowest: compound 3; then compounds 4, 2 and 1 (each within the scatter of the next).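

In this assay the swap of chloro for phenyl on the aromatic carbon now has a step of its own, a 2.1-fold higher number from compound 3 to compound 4 (0.33 log units; beyond the scatter), so the larger group costs some inhibition in the series with the unsubstituted benzyl group. With phenyl in place, the cyano on the benzyl group makes no readable difference, a 1.1-fold lower number from compound 2 to compound 4 (0.04 log units; within the scatter). Nothing measured here accounts for either step. From the compounds shown here alone, whether an amine or a carboxylic acid on this aromatic carbon would give a lower number stays open. So does the effect of cyano on the benzyl group when chloro is kept.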